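Cyclopropane Configuration Swap on a Pyridyl Diazabicycle

A few compounds are considered here, and "the series" means these few. Any claim that something is new, unique, unknown or untested is made for them only; others in the source may bear on it.

This account follows one step in a small set of ligands for an assay on a protein complex for displacement of a labelled ligand from Neuronal acetylcholine receptor; alpha4/beta2 (Rattus norvegicus), read by scintillation counting; on this read-out lower numbers stand for stronger inhibition and higher numbers for weaker inhibition. Compound 1 `COCC[C@H]1C[C@@H]1c1cncc(N2C[C@@H]3C[C@H]2CN3)c1` gives 6.2 nM and holds the highest number of the two measured compounds. Going by the values given here, its nearest neighbour is compound 2 `c1cncc(N2CC3CC2CN3)c1`, which gives 1 nM in this assay, a gap described as lying beyond the scatter; no single-site step between the two is recorded, so the gap is only what the two values show. Compound 3 `COCC[C@@H]1C[C@H]1c1cncc(N2C[C@@H]3C[C@H]2CN3)c1` is the next compound in line. The change from compound 1 to compound 3 is the two compounds have the same atoms and bonds and differ only in configuration as drawn: 2 of 4 stereo elements differ; a stereocentre at a saturated ring carbon is drawn R in compound 1 and S in compound 3; a stereocentre at a saturated ring carbon is drawn S in compound 1 and R in compound 3. With no comparable inversion among the measured compounds, the author expects a small step in this assay from compound 1 to compound 3, a 1.9-fold higher number from compound 1 to compound 3 (0.29 log units; within the scatter), toward a higher number, though a change within the scatter is also plausible. Compound 3 is therefore estimated at 12 nM, with a range from 3 nM to 50 nM.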

Compound 3, inhibition constant: 35.6 nM
Estimate against measurement, compound 3: 3.0-fold (0.47 log units) below; the range from low to high includes it.
By their numbers in this assay, from the lowest: compound 2; then compound 1; then compound 3.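

In this assay the inversion of both stereocentres at the saturated ring carbons gives a 5.7-fold higher number from compound 1 to compound 3 (0.76 log units; beyond the scatter), so this position responds to configuration as drawn and not only to which atoms are present. Going by these compounds alone, the two earlier compounds offered no single-site step, and this is the first change in the set that can be read at one place. The step can be tied to configuration alone, with no atom or bond entering or leaving, because the comparison rests on one fact: the fact that compounds 1 and 3 differ only in the configuration as drawn.

The compounds shown leave open how a form with only one of these two ring carbons inverted would read. They also leave open whether the same preference would hold with a carboxylic acid or an amine at the end of the chain in place of the methyl ether.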